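Swapping One Aryl Arm on a Shared Core

This account rests on a few compounds, and the source may have more. Where it says the series, first, only, none or still open, it means among the compounds named here.

In a functional assay on K562 cells (Homo sapiens) for cytotoxicity, read by MTT assay, with a stated time of 24 h (a higher number here means a weaker inhibitor, a lower number a stronger inhibitor), compound 1 (`COc1cc(/C=C2\CN(C)C/C(=C\c3ccc(F)cc3)C2=O)cc(OC)c1`) gives 11300 nM and compound 2 (`COc1cc(/C=C2\CN(C)C/C(=C\c3cc(OC)c(OC)c(OC)c3)C2=O)cc(OC)c1`) gives 3470 nM as the lower of the two numbers, a gap beyond the scatter. Compound 3 (`COc1cc(/C=C2\CN(C)C/C(=C\c3ccc(F)cc3)C2=O)cc(OC)c1OC`) differs from compound 2 by 4-fluorophenyl in place of 3,5-dimethoxyphenyl on a double-bonded chain carbon bound to a double-bonded ring carbon. In this assay a moderate rise in the number, meaning a weaker inhibitor, is expected because compound 1 with its 4-fluorophenyl gives 11300 nM there. The expected size is a 2.0-fold higher number from compound 2 to compound 3 (0.30 log units; within the scatter) in this read-out. Compound 3 is estimated at 7000 nM with an expected range of 3000 nM to 16000 nM here.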

Compound 3, half-maximal inhibitory concentration: 10300 nM
Compound 3: middle estimate off by 1.5-fold (0.17 log units), on the low side; the measured number falls inside the stated range.
By their numbers in this assay, from the lowest: compound 2; then compounds 3 and 1 (each within the scatter of the next).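

In this assay, 4-fluorophenyl in place of 3,5-dimethoxyphenyl on a double-bonded chain carbon bound to a double-bonded ring carbon gives a 3.0-fold higher number from compound 2 to compound 3 (0.47 log units; beyond the scatter), the first single-place step read at this position. Methoxy in place of hydrogen on an aromatic carbon gives a 1.1-fold lower number from compound 1 to compound 3 (0.04 log units; within the scatter), so this second change leaves the number within the scatter. Nothing measured here accounts for either step. As far as these compounds go, whether an amine or a carboxylic acid on the phenyl ring at that same carbon would shift the number remains open.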